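Swapping a Diketone Hydrazone for an Aryl Amidine

A few compounds are considered here, and "the series" means these few. Any claim that something is new, unique, unknown or untested is made for them only; others in the source may bear on it.

Compound 1, `CCOC(=O)C1=C(NN=C(C(C)=O)C(C)=O)Nc2[nH]nc(C)c2C1c1ccc(N(C)C)cc1`, is a weak inhibitor: in a functional assay on HeLa cells (Homo sapiens) for inhibition, read by MTT assay, with a stated time of 48 h (a lower number here means a stronger inhibitor, a higher number a weaker inhibitor), compound 1 gives 17000 nM. Compound 2, `CCOC(=O)C1=C(N/C=N/c2ncc(-c3ccccc3)s2)Nc2[nH]nc(C)c2C1c1ccc(N(C)C)cc1`, gives 15400 nM, a gap within the scatter, whereas compound 3, `CCOC(=O)C(=NNC1=C(C(=O)OCC)C(c2ccc(N(C)C)cc2)c2c(C)n[nH]c2N1)C(=O)OCC`, gives 83800 nM, reached by a 4.9-fold higher number from compound 1 to compound 3 (0.69 log units; beyond the scatter). Compound 4, `CCOC(=O)C1=C(N/C=N/c2ccc(C)cc2)Nc2[nH]nc(C)c2C1c1ccc(N(C)C)cc1`, differs from compound 1 by a group of 9 heavy atoms (8 carbon, 1 nitrogen; one six-membered aromatic ring of carbon only) in place of a group of 8 heavy atoms (5 carbon, 1 nitrogen, 2 oxygen; no ring), on an amine nitrogen. Among the compounds with values here, only that one step alters the same position, and it was modest; compound 2, which also carries an aromatic ring on that nitrogen, sits within the scatter of compound 1. The change is therefore expected to leave the number largely where it is. Compound 4 is estimated at 15000 nM, between 6000 nM and 40000 nM, an expected 1.1-fold lower number from compound 1 to compound 4 (0.05 log units; within the scatter).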

Compound 4, half-maximal inhibitory concentration: 43200 nM
Estimate against measurement, compound 4: 2.9-fold (0.46 log units) below; measured number outside the range, above it.
By their numbers in this assay, from the lowest: compounds 2 and 1 (each within the scatter of the next); then compounds 4 and 3 (each within the scatter of the next).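

On the amine nitrogen, carrying an aromatic ring does not by itself leave the number unchanged: in this assay there is a 2.5-fold higher number from compound 1 to compound 4 (0.41 log units; beyond the scatter) for this change. The ring's identity also counts, with a 2.8-fold higher number from compound 2 to compound 4 (0.45 log units; beyond the scatter) beyond the scatter when 4-methylphenyl replaces 5-phenyl-1,3-thiazol-2-yl on the double-bonded nitrogen, whereas a 1.9-fold lower number from compound 3 to compound 4 (0.29 log units; within the scatter) stays within the scatter, so those two compounds cannot be ranked.

As far as these compounds go, whether a 4-methoxyphenyl or pyridyl ring on that nitrogen would lie nearer compound 2 or compound 4 remains open. Nothing available explains these differences.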